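The source may hold more compounds than are shown below. What is called first, only, known or untested is meant among the compounds shown, and "the series" means these compounds.

Among the measured compounds shown here, in a functional assay on MCF7 cells (Homo sapiens) for antiproliferative activity, read by MTT assay, with a stated time of 72 h (on this read-out higher numbers stand for weaker inhibition and lower numbers for stronger inhibition), compound 3 (`COc1cc(-c2nc(C)sc2-c2ccc(C)cc2)cc(OC)c1OC`) gives 1740 nM, the middle of the three numbers so far: compound 1 (`CNc1nc(-c2cc(OC)c(OC)c(OC)c2)c(-c2ccc(C)cc2)s1`) gives 10.1 nM and compound 2 (`COc1ccc(-c2sc(N(C)C)nc2-c2cc(OC)c(OC)c(OC)c2)cc1`) gives 8360 nM. Compound 4 (`COc1ccc(-c2sc(C)nc2-c2cc(OC)c(OC)c(OC)c2)cc1`) differs from compound 3 by methoxy in place of methyl on an aromatic carbon. For the measured compounds named here, the only measured step, a 170-fold higher number from compound 1 to compound 3 (2.24 log units; beyond the scatter), is large but concerns another place, so it bears only weakly here. Compound 2 carries the 4-methoxyphenyl group but also differs elsewhere, so it isolates nothing. No step beyond the scatter is therefore expected in this assay. The estimated step is a 1.5-fold lower number from compound 3 to compound 4 (0.16 log units; within the scatter). For compound 4 the estimated value is 1200 nM, with an expected range from 250 nM to 6000 nM.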

Compound 4, half-maximal inhibitory concentration: 606 nM
For compound 4 the middle estimate is 2.0-fold (0.30 log units) above the measured one; the range from low to high includes it.
By their numbers in this assay, from the lowest: compound 1; then compound 4; then compound 3; then compound 2.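

Within this assay, changing 4-methylphenyl to 4-methoxyphenyl has a measurable effect on its own, modest but beyond the scatter (a 2.9-fold lower number from compound 3 to compound 4 (0.46 log units; beyond the scatter)). With 4-methoxyphenyl held fixed, methyl outperforms dimethylamino (a 14-fold lower number from compound 2 to compound 4 (1.14 log units; beyond the scatter)), whereas with 4-methylphenyl in place, methylamino outperforms methyl (a 170-fold higher number from compound 1 to compound 3 (2.24 log units; beyond the scatter)). No measurement on hand explains either step. Open, going by these compounds, is whether methylamino keeps its lead when paired with 4-methoxyphenyl. Also open, on these data alone, is how a chloro or ethoxy group would read at the position para to a large group.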